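A few compounds are considered here, and "the series" means these few. Any claim that something is new, unique, unknown or untested is made for them only; others in the source may bear on it.

Measured so far in a functional assay on HCT-116 cells (Homo sapiens) for inhibition, read by MTT assay, with a stated time of 48 h; a higher number here means a weaker inhibitor, a lower number a stronger inhibitor:
- Compound 1 `COc1ccc(-n2c(S)nnc2-c2cc(OC)c(OC)c(OC)c2)cc1`: > 60000 nM, a limit
- Compound 2 `COc1ccc(-n2c(SCC(=O)Nc3ccc(Cl)cc3)nnc2-c2cc(OC)c(OC)c(OC)c2)cc1`: > 60000 nM, a limit
- Compound 3 `COc1cc(-c2nnc(S)n2-c2ccc(N(C)C)cc2)cc(OC)c1OC`: > 60000 nM, a limit

Compound 3 has a limit and no number, so it cannot be ranked within the series. The record so far is the limit of > 60000 nM in this assay, at which 3 of the 3 values shown sit.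

Compound 4 `COc1ccc(C(=O)CSc2nnc(-c3cc(OC)c(OC)c(OC)c3)n2-c2ccc(N(C)C)cc2)cc1` keeps the structure of compound 3 except for one change, ((4-methoxyphenyl)carbonyl)methyl in place of hydrogen on a sulfur.

Among the measured compounds shown here, two measured steps bear on this change. The closer one is a step that the two limits leave unreadable from compound 1 to compound 2, which also replaces hydrogen on a sulfur, though with a different group. The other is a step that the two limits leave unreadable from compound 1 to compound 3, which introduces the dimethylamino group shared by compound 3 and compound 4. Neither step has a readable size, so neither supplies a measured size or direction.

Compound 2, substituted on the sulfur, gives > 60000 nM, again a limit. A further limit is therefore a likely outcome, and any number is expected to lie close to it. The expected step, a weakly supported estimate, is an at least 2.0-fold lower number from compound 3 to compound 4 (0.30 log units; that floor lies within the scatter). The estimated value for compound 4 is 30000 nM, with an expected range of 5000 nM to 60000 nM.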

Compound 4, half-maximal inhibitory concentration: > 60000 nM
Compound 4: a limit, no number; the forecaster's own chance of this, stated with the estimate: 55%; middle value at least 2.0-fold (0.30 log units) away from the limit.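

In this assay compound 4 gives > 60000 nM, a limit and not a number. Among the compounds shown here, compound 3 also carries only a limit, so no step from compound 3 to compound 4 can be read. The compounds shown leave open whether any change to the shared core yields a readable number: the limit of > 60000 nM in this assay, at which 4 of the 4 values shown sit.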